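Swapping the terminal amide for a ketone on the shared core

The source may hold more compounds than are shown below. What is called first, only, known or untested is meant among the compounds shown, and "the series" means these compounds.

Measured compounds:
compound 1, `N#C/C(=C\N1CCN(C(=O)c2ccco2)C1=S)C(=O)Nc1ccc(Cl)cc1`, 25600 nM
compound 2, `N#C/C(=C\N1CCN(C(=O)c2ccco2)C1=S)C(N)=O`, 24900 nM

Both compounds were tested in a functional assay on COLO 205 cells (Homo sapiens) for inhibition, read by sulforhodamine B assay, with a stated time of 48 h; a higher number here means a weaker inhibitor of growth, a lower number a stronger inhibitor of growth. Compound 2 gives 24900 nM, the lowest of the two numbers, but compound 1 sits within the scatter of it. Within the data shown here, the only measured step, a 1.0-fold lower number from compound 1 to compound 2 (0.01 log units; within the scatter), exchanged the group on the amide nitrogen and changed nothing beyond the scatter.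

Compound 3, `N#C/C(=C\N1CCN(C(=O)c2ccco2)C1=S)C(=O)c1ccccc1`, differs from compound 2 in another way: phenyl in place of amino on a carbonyl carbon, that is, carbamoyl to benzoyl. Among the measured compounds shown here, no measured step touches this carbonyl carbon, so the step from compound 1 to compound 2 gives only weak guidance: it shows that the end of this chain tolerated a large change without effect. On that basis the step of a 1.2-fold lower number from compound 2 to compound 3 (0.10 log units; within the scatter) is expected to stay small, in either direction. Compound 3 is therefore estimated at 20000 nM, with a range from 6000 nM to 60000 nM.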

Compound 3, concentration for 50% growth inhibition: 23200 nM
Estimate against measurement, compound 3: 1.2-fold (0.06 log units) below, within the range that was stated.
By their numbers in this assay, from the lowest: compounds 3, 2 and 1 (each within the scatter of the next).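

Until now only the group on the amide nitrogen had changed; here the nitrogen itself goes. In this assay, phenyl in place of amino on the carbonyl carbon gives a 1.1-fold lower number from compound 2 to compound 3 (0.03 log units; within the scatter), and phenyl in place of (4-chlorophenyl)amino gives a 1.1-fold lower number from compound 1 to compound 3 (0.04 log units; within the scatter), so the carbamoyl, the 4-chlorophenyl amide and the benzoyl cannot be told apart at this position. Nothing measured here explains this lack of difference.

On these data alone, it remains open whether any group on this carbonyl carbon can move the number beyond the scatter, for example a carboxylic acid, a methyl ester or a piperazine amide. The rest of the shared core is the same in all three compounds, so these results say nothing about changes made there.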